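The source may hold more compounds than are shown below. What is called first, only, known or untested is meant among the compounds shown, and "the series" means these compounds.

Measured so far:
- compound 1, `COc1cc(-n2ncnc2-c2cccc([N+](=O)[O-])c2)cc(OC)c1OC` — in a functional assay on K562 cells (Homo sapiens) for antiproliferative activity, read by MTT assay, with a stated time of 72 h (on this read-out higher numbers stand for weaker inhibition and lower numbers for stronger inhibition), compound 1 gives > 10000 nM, a limit of the assay and not a number.
- compound 2, `COc1cc(-n2ncnc2-c2ccc(OC(C)C)cc2)cc(OC)c1OC` — in this assay compound 2 gives 800 nM.
- compound 3, `COc1cc(-c2ncnn2-c2cccc(N)c2)cc(OC)c1OC` — in this assay compound 3 gives > 10000 nM, again a limit.

Among the compounds with values here, compound 3 therefore stands at the edge of what this assay can report: no number is known for it, only that the true value lies past the limit. The same is true of compound 1, so (the limit of > 10000 nM in this assay, at which 2 of the 3 values shown sit), and compound 2 alone carries a measured number. Within the data shown here, no pair of these three differs in a single place, so no measured step is available in this assay to calibrate the change below.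

Compound 4, `COc1cc(-c2ncnn2-c2ccc(F)cc2)cc(OC)c1OC`, is the next compound. 4-fluorophenyl in place of 3-aminophenyl on an aromatic nitrogen

Among the measured compounds shown here, the only substituted-phenyl member with a number is compound 2, whose value in this assay shows that a measurable value is reachable; compound 1 and compound 3, both at the limit, show that it is not reached by every such group. For the step from compound 3 to compound 4 the expectation is an at least 1.6-fold lower number from compound 3 to compound 4 (0.22 log units; that floor lies within the scatter), a move toward the measurable range but with a real chance of another limit. Compound 4 is thus expected at 6000 nM in this assay, within 1500 nM to 20000 nM.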

Compound 4, half-maximal inhibitory concentration: > 10000 nM
Compound 4: a limit, no number; the forecaster's own chance of this, stated with the estimate: 50%; at least 1.6-fold (0.22 log units) between middle value and limit.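

Compound 4 also stands at a limit of the assay and gives no number, as does compound 3, so no step between compound 3 and compound 4 can be read: the limit of > 10000 nM in this assay, at which 3 of the 4 values shown sit.

The compounds shown leave open whether 4-fluorophenyl in place of 3-aminophenyl on an aromatic nitrogen changes the true value at all, and in which direction.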